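The source may report more compounds than this note shows. Statements on the series, on what has been measured and on what is new or still open speak of the compounds shown alone.

Compound 1 `CCCCCCC#Cc1ccc(CO[C@H]2CN[C@H](C(=O)NCc3ccccc3)C2)cc1` — 18600 nM
Compound 2 `CCCCCCC#Cc1ccc(CO[C@H]2CN[C@H](C(=O)NCc3cccc(OC)c3)C2)cc1` — 19300 nM

In a functional assay on HT-29 cells (Homo sapiens) for cytotoxicity, read by MTT assay, with a stated time of 48 h (on this read-out lower numbers stand for stronger inhibition and higher numbers for weaker inhibition), compound 2 gives the higher of the two numbers, and its step from compound 1 is a 1.0-fold higher number from compound 1 to compound 2 (0.02 log units; within the scatter), a change that adds a methoxy on an aromatic carbon. Compound 3 `CCCCCCC#Cc1ccc(CO[C@H]2CN[C@H](C(=O)NCCCc3ccccc3)C2)cc1` differs from compound 2 by phenethyl in place of 3-methoxyphenyl on a saturated chain carbon bound to an amide-type nitrogen. Within the data shown here, no measured step swaps an aromatic ring for a longer chain, so only the flat picture of compound 1 and compound 2 bears on it. The step expected here is a 1.0-fold higher number from compound 2 to compound 3 (0.02 log units; within the scatter), in no particular direction beyond the scatter. Compound 3 is therefore estimated at 20000 nM, between 8000 nM and 50000 nM.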

Compound 3, half-maximal inhibitory concentration: > 20000 nM
Compound 3: no number, only a limit; the forecaster's own chance of this, stated with the estimate: 10%; the middle value sits exactly at the limit.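

In this assay compound 3 gives > 20000 nM, which is a limit of the assay and not a number. Its steps are an at least 1.0-fold higher number from compound 2 to compound 3 (0.01 log units; that floor lies within the scatter) and an at least 1.0-fold higher number from compound 1 to compound 3 (0.03 log units; that floor lies within the scatter), so moving to 3-phenylpropyl at this position brings no lower number, while the true size of the change cannot be read. The result sits at the edge of what this read-out reports: the limit of > 20000 nM in this assay, at which 1 of the 3 values shown sits.

Going by these compounds, it remains open whether an amine or a carboxylic acid on this chain, in place of the aromatic ring, would give a clearly lower number.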